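The compounds below may be only part of what the source reports. "The series", "measured", "known", "first", "only" and "open" are said of these compounds alone.

In a functional assay on the whole organism for antagonist activity, with Mus musculus as the target (on this read-out lower numbers stand for an effect already at smaller amounts and higher numbers for an effect only at larger amounts of compound), the measured compounds read as follows

Compound 1 (`CN(C(=O)CNC(=O)CN1CCCCC1)c1ccc(Cl)cc1C(=O)c1ccccc1Cl`) gives 7.5 mg/kg
Compound 2 (`CC(C)NCC(=O)NCC(=O)N(C)c1ccc(Cl)cc1C(=O)c1ccccc1Cl`) gives 1 mg/kg
Compound 3 (`NCC(=O)NCC(=O)Nc1ccc([N+](=O)[O-])cc1C(=O)c1ccccc1`) gives 4.82 mg/kg

Compound 2 stands lowest of the three, with compound 3 and compound 1 both higher beyond the scatter. Still unmeasured, compound 4 (`CN1CCN(CC(=O)NCC(=O)N(C)c2ccc(Cl)cc2C(=O)c2ccccc2Cl)CC1`) carries 4-methylpiperazin-1-yl in place of isopropylamino on a saturated chain carbon bound to a carbonyl carbon . Within the data shown here, one measured step bears on this change at the same place: a 7.5-fold lower number from compound 1 to compound 2 (0.88 log units; beyond the scatter) came with isopropylamino replacing piperidin-1-yl. Among the measured compounds shown here, compound 4 reverses that direction by restoring a six-membered non-aromatic ring, although no measured compound carries 4-methylpiperazin-1-yl. A similar or somewhat smaller rise in this assay therefore seems likely. The expected step is a 5.0-fold higher number from compound 2 to compound 4 (0.70 log units; beyond the scatter). For compound 4 the estimated value is 5 mg/kg, with an expected range from 1.5 mg/kg to 15 mg/kg.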

Compound 4, dose for half-maximal effect: 59 mg/kg
Compound 4: the middle estimate sits 12-fold (1.07 log units) below what was measured, outside the stated range (above it).
By their numbers in this assay, from the lowest: compound 2; then compounds 3 and 1 (each within the scatter of the next); then compound 4.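

In this assay, among these compounds, this place on a saturated chain carbon bound to a carbonyl carbon tolerates far less than the earlier compounds suggested, with a large rise of a 59-fold higher number from compound 2 to compound 4 (1.77 log units; beyond the scatter). The six-membered ring alone does not set the number: with a ring kept at this place, 4-methylpiperazin-1-yl in place of piperidin-1-yl still gives a 7.9-fold higher number from compound 1 to compound 4 (0.90 log units; beyond the scatter). Nothing available here explains either step. Still open, going by these compounds, is whether the rise follows the methyl or the second ring nitrogen, which piperazin-1-yl and morpholin-4-yl at this place could separate.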